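Pyridine series: 2-chlorophenyl for furan-2-yl at position 3

This account rests on a few compounds, and the source may have more. Where it says the series, first, only, none or still open, it means among the compounds named here.

Measured compounds in a functional assay on K562 cells (Homo sapiens) for cytotoxicity, in the presence of a further agent that is not named here; a higher number here means a weaker inhibitor, a lower number a stronger inhibitor:
- compound 1 `Clc1ccc(-c2cc(-c3ccsc3)nc(-c3ccccc3Cl)c2)o1`: in this assay compound 1 gives 17200 nM
- compound 2 `Clc1ccc(-c2cc(-c3cccnc3)nc(-c3cccs3)c2)o1`: in this assay compound 2 gives 22300 nM
- compound 3 `Clc1ccc(-c2cc(-c3ccco3)nc(-c3cccs3)c2)o1`: in this assay compound 3 gives 16000 nM

Compound 3 holds the lowest of the three numbers, but its gaps to compound 1 and compound 2 are both within the scatter, so the three sit together and none can be called stronger or weaker than another. For the measured compounds named here, the only single-point step measured, a 1.4-fold lower number from compound 2 to compound 3 (0.14 log units; within the scatter), is itself within the scatter.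

Compound 4 `Clc1ccc(-c2cc(-c3cccs3)nc(-c3ccccc3Cl)c2)o1` is not yet measured. It differs from compound 3 by 2-chlorophenyl in place of furan-2-yl on an aromatic carbon. Compound 1 also carries a 2-chlorophenyl group on the shared core and gives 17200 nM, a number indistinguishable from that of compound 3. The step from compound 2 to compound 3 bears on it only loosely, and it was flat. For compound 4 in this assay the expected step is therefore a 1.1-fold higher number from compound 3 to compound 4 (0.05 log units; within the scatter), with no movement beyond the scatter. The estimate for compound 4 is 18000 nM, within 9000 nM to 36000 nM.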

Compound 4, half-maximal inhibitory concentration: 17200 nM
Compound 4: middle estimate off by 1.0-fold (0.02 log units), on the high side, and the stated range covers the measured number.
By their numbers in this assay, from the lowest: compounds 3, 1, 4 and 2 (each within the scatter of the next).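

In this assay 2-chlorophenyl in place of furan-2-yl gives a 1.1-fold higher number from compound 3 to compound 4 (0.03 log units; within the scatter) on the aromatic carbon next to the ring nitrogen, and 2-chlorophenyl in place of pyridin-3-yl gives a 1.3-fold lower number from compound 2 to compound 4 (0.11 log units; within the scatter) at the same carbon. With thiophen-2-yl held, this position therefore takes furan-2-yl, pyridin-3-yl or 2-chlorophenyl without a step beyond the scatter, although the entering 2-chlorophenyl has 7 heavy atoms and no hydrogen-bond acceptor, against 5 heavy atoms and 1 acceptor for furan-2-yl. With 2-chlorophenyl held, thiophen-2-yl in place of thiophen-3-yl gives no change at the digits printed from compound 1 to compound 4 (within the scatter) and is equally flat.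

No evidence on the cause of these flat steps is available. From the compounds shown here alone, every group compared here is an aromatic ring, so it remains open whether an amine, a carboxylic acid or a longer alkyl chain at this position would move the number beyond the scatter.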